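This account rests on a few compounds, and the source may have more. Where it says the series, first, only, none or still open, it means among the compounds named here.

Measured so far:
- compound 1, `CCCCCCCCCCCCNc1nc(SCc2ccc(C(F)(F)F)cc2)nc2ccccc12`: 26000 nM
- compound 2, `FC(F)(F)c1ccc(CSc2nc(Nc3ccccc3)c3ccccc3n2)cc1`: 20000 nM
- compound 3, `FC(F)(F)c1ccc(CSc2nc(Nc3ccccc3C(F)(F)F)c3ccccc3n2)cc1`: 34800 nM

All three were tested in a functional assay on PC-3 cells (Homo sapiens) for cytotoxicity, read by MTT assay, with a stated time of 72 h; a lower number here means a stronger inhibitor, a higher number a weaker inhibitor. Compound 2 gives 20000 nM there, and the numbers for compound 1 and compound 3 both lie within the usual scatter of that value, so none of the three can be called a stronger or weaker inhibitor than another.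

The step from compound 2 to compound 4, `O=[N+]([O-])c1cccc(Nc2nc(SCc3ccc(C(F)(F)F)cc3)nc3ccccc23)c1`, is a single substitution: nitro in place of hydrogen on an aromatic carbon. Among the compounds with values here, the only measured step that touches this part of the molecule is the one from compound 2 to compound 3, where a different group was placed on the same ring and the result was a 1.7-fold higher number from compound 2 to compound 3 (0.24 log units; within the scatter). That step stayed within the scatter. A group entering on this ring has not so far moved the number, so for compound 4 no step beyond the scatter is expected in either direction, with the expected change being a 1.1-fold higher number from compound 2 to compound 4 (0.04 log units; within the scatter).

Compound 4 is therefore estimated at 22000 nM, with a likely range from 9000 nM to 55000 nM.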

Compound 4, half-maximal inhibitory concentration: 13500 nM
Beside the measured number, compound 4's estimate is 1.6-fold (0.21 log units) above it; measured number inside the range.
By their numbers in this assay, from the lowest: compounds 4, 2, 1 and 3 (each within the scatter of the next, the first and the last beyond it).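

In this assay nitro on the anilino ring gives a 1.5-fold lower number from compound 2 to compound 4 (0.17 log units; within the scatter) and so, like trifluoromethyl on that ring, does not shift the number measurably from that of the plain phenyl group. The two substituted rings can still be told apart, with a 2.6-fold lower number from compound 3 to compound 4 (0.41 log units; beyond the scatter) in a swap of 2-(trifluoromethyl)phenyl for 3-nitrophenyl that changes both the group and its place on the ring. No measurement available here explains this gap.

Within the data shown here, because nitro and trifluoromethyl each appear at only one place on the ring, these compounds cannot show whether the gap follows the group or its position. As far as these compounds go, whether an amine or a carboxylic acid on this ring would move the number beyond the scatter from compound 2 also stays open.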